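From 3,5-dichlorophenyl to 4-hydroxy-3-methoxyphenyl: an expected cytotoxicity step

The source may report more compounds than this note shows. Statements on the series, on what has been measured and on what is new or still open speak of the compounds shown alone.

Measured in a functional assay on HT-1080 cells (Homo sapiens) for cytotoxicity, read by MTT assay, with a stated time of 72 h; a higher number here means a weaker inhibitor, a lower number a stronger inhibitor:
- compound 1 `COc1cccc(/C=C2\CCC/C(=C\c3ccccc3Br)C2=O)c1OC`: 10800 nM
- compound 2 `COc1cccc(/C=C2\CCC/C(=C\c3cc(Cl)cc(Cl)c3)C2=O)c1OC`: 6100 nM

Compound 2, at 6100 nM, stands level with compound 1, at 10800 nM, since the two numbers lie within the scatter of each other. Compound 3 `COc1cc(/C=C2\CCC/C(=C\c3cccc(OC)c3OC)C2=O)ccc1O` has not yet been measured and differs from compound 2 in one place: 4-hydroxy-3-methoxyphenyl in place of 3,5-dichlorophenyl on a double-bonded chain carbon bound to a double-bonded ring carbon. There, 4-hydroxy-3-methoxyphenyl takes the place of 3,5-dichlorophenyl on a double-bonded chain carbon bound to a double-bonded ring carbon.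

Going by the values given here, only one measured step bears on this place: a 1.8-fold lower number from compound 1 to compound 2 (0.25 log units; within the scatter). Neither measured compound carries 4-hydroxy-3-methoxyphenyl, so this evidence is indirect, and no change beyond the scatter is expected in this assay. The expected step is a 1.2-fold lower number from compound 2 to compound 3 (0.09 log units; within the scatter). For compound 3 the estimated value is 5000 nM, with an estimated range of 1800 nM to 14000 nM.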

Compound 3, half-maximal inhibitory concentration: 5900 nM
Estimate against measurement, compound 3: 1.2-fold (0.07 log units) below; the range from low to high includes it.
By their numbers in this assay, from the lowest: compounds 3, 2 and 1 (each within the scatter of the next).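

In this assay the place on a double-bonded chain carbon bound to a double-bonded ring carbon now carries a group without halogen: 4-hydroxy-3-methoxyphenyl, with a hydrogen-bond donor that neither 3,5-dichlorophenyl nor 2-bromophenyl has, gives a 1.0-fold lower number from compound 2 to compound 3 (0.01 log units; within the scatter) and a 1.8-fold lower number from compound 1 to compound 3 (0.26 log units; within the scatter) as its two steps. Going by these compounds alone, the earlier pair set only two halogen-bearing groups against each other, whereas the three compounds now stand level across both chlorine or bromine and hydroxy with methoxy at this place. Nothing available explains why the numbers stay level.

As far as these compounds go, whether an amine or a carboxylic acid at this place would move the number beyond the scatter remains open. So does whether 4-hydroxy-3-methoxyphenyl would behave the same way with a different group on the other side of the shared core.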